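Removing the fluorine from the benzyl amide of compound 3

The source may report more compounds than this note shows. Statements on the series, on what has been measured and on what is new or still open speak of the compounds shown alone.

Of the compounds shown here, three of one shared core have been measured in an assay on cells for inhibition of Voltage-dependent T-type calcium channel subunit alpha-1G (Homo sapiens), read by patch clamp; on this read-out lower numbers stand for stronger inhibition and higher numbers for weaker inhibition. Compound 1 `CN(C)CCCCCSC1=Nc2ccccc2C(CC(=O)NCc2ccccc2)N1c1ccc(-c2ccc(F)cc2)cc1` gives 250 nM, compound 2 `CN(C)CCCCCSC1=Nc2ccccc2C(CC(=O)NCc2ccccc2)N1c1ccc(-c2ccccc2)cc1` gives 7770 nM, and compound 3 `CN(C)CCCCCSC1=Nc2ccccc2C(CC(=O)NCc2ccc(F)cc2)N1c1ccccc1` gives 555000 nM. Compound 3 therefore stands highest of the three numbers, well beyond the scatter from both others, with compound 2 nearest and compound 1 furthest away.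

Compound 4 `CN(C)CCCCCSC1=Nc2ccccc2C(CC(=O)NCc2ccccc2)N1c1ccccc1` follows from compound 3 by hydrogen in place of fluoro on an aromatic carbon. Among the compounds with values here, the only measured step of the same kind is a 31-fold higher number from compound 1 to compound 2 (1.49 log units; beyond the scatter), where the fluorine sits on the biphenyl rather than on the benzyl amide, so it bears on the new step only loosely. Within the data shown here, no step between compound 2 and compound 4 is on record; their structures differ in the biphenyl against the plain phenyl, and only the two values can be compared once compound 4 is known.

Given that loose analogy, and given that compound 3 already gives 555000 nM, compound 4 is expected to stay in the same weak region, with the estimated step of a 1.4-fold lower number from compound 3 to compound 4 (0.14 log units; within the scatter) and an estimate of 400000 nM, ranging from 80000 nM to 2000000 nM.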

Compound 4, half-maximal inhibitory concentration: 18500 nM
The estimate for compound 4 lay 22-fold (1.33 log units) above the measured number, and the stated range ends above it.
By their numbers in this assay, from the lowest: compound 1; then compound 2; then compound 4; then compound 3.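

In this assay, hydrogen in place of fluoro on an aromatic carbon, para to a large group, gives a large drop on the benzyl amide (a 30-fold lower number from compound 3 to compound 4 (1.48 log units; beyond the scatter)), so this change does not run in one direction across the shared core, and the position of the fluorine decides its sign: the same change on two cores in this assay, a 31-fold higher number (1.49 log units; beyond the scatter) from compound 1 to compound 2 and a 30-fold lower number (1.48 log units; beyond the scatter) from compound 3 to compound 4, 930-fold (2.97 log units) apart, beyond the scatter of two such steps. Compound 4 also shows that hydrogen in place of phenyl is only a modest step (a 2.4-fold higher number from compound 2 to compound 4 (0.38 log units; beyond the scatter)), whereas hydrogen in place of 4-fluorophenyl is a large one (a 74-fold higher number from compound 1 to compound 4 (1.87 log units; beyond the scatter)), so most of the difference between compound 1 and compound 4 appears only with the fluorine present. Among these four compounds, fluoro on the benzyl amide goes with a higher number and fluoro on the outer phenyl with a lower one.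

On these data alone, whether chloro or methoxy at the same place on the benzyl amide would follow fluoro or hydrogen remains open. So does the result of carrying 4-fluorobenzyl and 4-fluorophenyl together on one compound, which would show whether the two places act independently.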